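A few compounds are considered here, and "the series" means these few. Any claim that something is new, unique, unknown or untested is made for them only; others in the source may bear on it.

Of the compounds shown here, three of the shared core have been measured in a functional assay on P388D1 cells (Mus musculus) for antiproliferative activity, read by MTT assay; on this read-out higher numbers stand for weaker inhibition and lower numbers for stronger inhibition. Compound 1 `COC(=O)N1CCCc2cc(S(=O)(=O)N3CC(c4ccccc4)NC3=O)ccc21` gives 2260 nM, compound 2 `CCCOC(=O)N1CCCc2cc(S(=O)(=O)N3CC(c4ccccc4)NC3=O)ccc21` gives 2020 nM and compound 3 `O=C(OCCCl)N1CCCc2cc(S(=O)(=O)N3CC(c4ccccc4)NC3=O)ccc21` gives 1210 nM. Compound 3 has the lowest of the three numbers, but the steps of a 1.9-fold lower number from compound 1 to compound 3 (0.27 log units; within the scatter) and a 1.7-fold lower number from compound 2 to compound 3 (0.22 log units; within the scatter) are within the scatter, as is a 1.1-fold lower number from compound 1 to compound 2 (0.05 log units; within the scatter); across the three, the ester side of the carbonyl has been varied without a step beyond the scatter.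

Compound 4 `O=C(NC1CCCCC1)N1CCCc2cc(S(=O)(=O)N3CC(c4ccccc4)NC3=O)ccc21` is not yet measured. It differs from compound 3 as follows: cyclohexylamino in place of 2-chloroethoxy on a carbonyl carbon.

Among the measured compounds shown here, none of the measured steps bears on this change directly: each of them alters only the group on the oxygen of the carbonyl, and a nitrogen-linked substituent on that carbonyl carbon has no precedent here. The three measured steps all lie within the scatter, so the default expectation is a step of similar size. For compound 4 the expectation is a 1.2-fold higher number from compound 3 to compound 4 (0.09 log units; within the scatter), giving an estimated 1500 nM, with a range from 500 nM to 5000 nM in this assay.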

Compound 4, half-maximal inhibitory concentration: 8160 nM
Beside the measured number, compound 4's estimate is 5.4-fold (0.74 log units) below it; measured number above the stated range.
By their numbers in this assay, from the lowest: compounds 3, 2 and 1 (each within the scatter of the next); then compound 4.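

Cyclohexylamino on the carbonyl carbon gives the first steps in this series beyond the scatter in this assay: a 6.7-fold higher number from compound 3 to compound 4 (0.83 log units; beyond the scatter) and a 4.0-fold higher number from compound 2 to compound 4 (0.61 log units; beyond the scatter) and a 3.6-fold higher number from compound 1 to compound 4 (0.56 log units; beyond the scatter). All three steps point the same way, towards weaker inhibition, so this position is not indifferent to every change, even though methoxy, propoxy and 2-chloroethoxy remain within the scatter of one another. No measurement on hand gives a reason for this loss.

As far as these compounds go, the change swaps the linking atom and the group on it at once, so it remains open whether the nitrogen link or the cyclohexyl ring carries the step; cyclohexyloxy and propylamino on the same carbonyl carbon would tell these apart. Also open, from the compounds shown here alone, is how a smaller amine such as methylamino would read.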